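Swapping the bromoalkyl ether for an acetyl group

The source may report more compounds than this note shows. Statements on the series, on what has been measured and on what is new or still open speak of the compounds shown alone.

Compound 1, `C=CCOc1c(Br)cc(Br)cc1Oc1ccc(Br)cc1Br`, gives 27.9 ug/mL in a functional assay on HL-60 cells (Homo sapiens) for cytotoxicity, read by MTT assay, with a stated time of 24 h; on this read-out lower numbers stand for stronger inhibition and higher numbers for weaker inhibition.
Compound 2, `C#CCOc1c(Br)cc(Br)cc1Oc1ccc(Br)cc1Br`, gives 29.7 ug/mL.
Compound 3, `BrCCCCCCOc1c(Br)cc(Br)cc1Oc1ccc(Br)cc1Br`, gives 37.8 ug/mL.

Compound 3 carries the highest of the three numbers, yet each step towards it stays within the scatter: a 1.4-fold higher number from compound 1 to compound 3 (0.13 log units; within the scatter), and a 1.3-fold higher number from compound 2 to compound 3 (0.10 log units; within the scatter). Compound 4, `CC(=O)Oc1c(Br)cc(Br)cc1Oc1ccc(Br)cc1Br`, differs from compound 3 by acetyl in place of 6-bromohexyl on an oxygen on an aromatic ring. The two steps just named are the ones that bear on this change, since each also replaces the group on that same aromatic oxygen, and both were small. On that basis no step beyond the scatter is expected, so the step to compound 4 is estimated as a 1.2-fold lower number from compound 3 to compound 4 (0.07 log units; within the scatter). The value expected for compound 4 is 32 ug/mL, with a range from 14 ug/mL to 75 ug/mL.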

Compound 4, half-maximal inhibitory concentration: 29.9 ug/mL
For compound 4 the middle estimate is 1.1-fold (0.03 log units) above the measured one; low and high end bracket the measured number.
By their numbers in this assay, from the lowest: compounds 1, 2, 4 and 3 (each within the scatter of the next).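

Unlike allyl, propargyl and 6-bromohexyl, acetyl carries a carbonyl, yet this assay shows no readable shift on this aromatic oxygen (a 1.3-fold lower number from compound 3 to compound 4 (0.10 log units; within the scatter); a 1.0-fold higher number from compound 2 to compound 4 (0.00 log units; within the scatter); a 1.1-fold higher number from compound 1 to compound 4 (0.03 log units; within the scatter)). A short acetyl and a long bromoalkyl chain therefore stay within the scatter of each other here, so this swap leaves the cytotoxicity read-out effectively unchanged.

Going by these compounds, what a chain ending in an amine or a carboxylic acid would do on this oxygen remains open. Nothing measured here explains why these four groups read so alike.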